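A few compounds are considered here, and "the series" means these few. Any claim that something is new, unique, unknown or untested is made for them only; others in the source may bear on it.

Compound 1 `CC(=O)n1nc(C)c(-c2ccc(Cl)c(Cl)c2)c1N` and compound 2 `Cc1nn(C(=O)C2CCCC2)c(N)c1-c1ccc(Cl)c(Cl)c1` share one core and differ only in the group on the carbonyl carbon. In an assay on Sf9 cells for inhibition of inhibitor of nuclear factor kappa-B kinase subunit epsilon (Homo sapiens), read by ADP-Glo, with a stated time of 60 min (on this read-out lower numbers stand for stronger inhibition and higher numbers for weaker inhibition), compound 1 reaches only the assay limit, > 100000 nM. Compound 2 likewise shows only a limit in this assay, > 100000 nM. The step that the two limits leave unreadable from compound 1 to compound 2 is thus unreadable because the limit of > 100000 nM in this assay, at which 2 of the 2 values shown sit, covers both values. Compound 3 `Cc1nn(C(=O)c2ccccc2)c(N)c1-c1ccc(Cl)c(Cl)c1` carries phenyl in place of cyclopentyl on a carbonyl carbon. For the measured compounds named here, the single measured step gives no readable size, so no direction can be drawn from it. Compound 3 is therefore expected near the same limit, estimated at 150000 nM in this assay, between 30000 nM and 1000000 nM. The expected step that the limit leaves unreadable from compound 2 to compound 3 is none beyond the scatter.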

Compound 3, half-maximal inhibitory concentration: > 100000 nM
Compound 3: only a limit was reported (the forecaster's own chance of this, stated with the estimate: 85%); the middle value lies beyond the limit too.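

Compound 3 also gives only a limit in this assay, so no step among compound 1, compound 2 and compound 3 can be read: the limit of > 100000 nM in this assay, at which 3 of the 3 values shown sit.

The compounds shown leave open whether any group on the carbonyl carbon of the shared core gives a measurable value in this assay.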